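Changing one side chain: compound 3 to compound 4

A few compounds are considered here, and "the series" means these few. Any claim that something is new, unique, unknown or untested is made for them only; others in the source may bear on it.

In a functional assay on K562 cells (Homo sapiens) for cytotoxicity, read by trypan blue exclusion, with a stated time of 96 h (on this read-out higher numbers stand for weaker inhibition and lower numbers for stronger inhibition), compound 1 `COc1ccc(/C=C/S(=O)(=O)Nc2c(F)c(F)c(F)c(F)c2F)cc1N` gives 35000 nM, compound 2 `COc1cc(OC)c(/C=C/S(=O)(=O)Nc2ccc(OC)c([N+](=O)[O-])c2)c(OC)c1` gives 1000 nM, and compound 3 `COC(=O)C(C)Nc1cc(NS(=O)(=O)/C=C/c2c(OC)cc(OC)cc2OC)ccc1OC` gives 300 nM, the lowest of these three numbers. Compound 4 `COc1cc(OC)c(/C=C/S(=O)(=O)Nc2ccc(OC)c(NCC(=O)O)c2)c(OC)c1` has not been measured. It carries carboxymethyl in place of 1-(methoxycarbonyl)ethyl on a nitrogen on an aromatic ring. For the measured compounds named here, the only measured step that bears on this is a 3.3-fold lower number from compound 2 to compound 3 (0.52 log units; beyond the scatter), which installed the group now leaving. Going by the values given here, no measured step swaps one group on that nitrogen for another, so the direction is uncertain. A modest loss of strength is the expectation, estimated as a 2.3-fold higher number from compound 3 to compound 4 (0.37 log units; beyond the scatter). For compound 4 the expected value in this assay is 700 nM, with an estimated range of 120 nM to 4000 nM.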

Compound 4, half-maximal inhibitory concentration: 20 nM
Compound 4: middle estimate off by 35-fold (1.54 log units), on the high side; measured number outside the range, below it.
By their numbers in this assay, from the lowest: compound 4; then compound 3; then compound 2; then compound 1.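

In this assay, for the compounds shown here, the group on this nitrogen matters far more than the earlier compounds showed: carboxymethyl in place of 1-(methoxycarbonyl)ethyl gives a 15-fold lower number from compound 3 to compound 4 (1.18 log units; beyond the scatter). Measured against the nitro compound, (carboxymethyl)amino gives a 50-fold lower number from compound 2 to compound 4 (1.70 log units; beyond the scatter), a much larger step than the one to the ester. No measurement shown here accounts for this gain.

The ester and the methyl branch leave together, so either change could carry the step. A 1-carboxyethyl or a methoxycarbonylmethyl group on this nitrogen would separate them.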